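A few compounds are considered here, and "the series" means these few. Any claim that something is new, unique, unknown or untested is made for them only; others in the source may bear on it.

Measured in a functional assay on DU-145 cells (Homo sapiens) for antiproliferative activity, read by MTT assay, with a stated time of 48 h; a higher number here means a weaker inhibitor, a lower number a stronger inhibitor:
- Compound 1 `C/C(=C\CC/C(C)=C/CC[C@@H]1[C@@]2(C)CCC(=O)C(C)(C)[C@H]2CC[C@@]1(C)O)CC/C=C(\C)C(=O)OCc1cn(-c2cccc([N+](=O)[O-])c2)nn1`: > 150000 nM (a limit)
- Compound 2 `COc1ccc(-n2cc(COC(=O)/C(C)=C/CC/C(C)=C/CC/C(C)=C/CC[C@@H]3[C@@]4(C)CCC(=O)C(C)(C)[C@H]4CC[C@@]3(C)O)nn2)cc1`: 135000 nM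
- Compound 3 `C/C(=C\CC/C(C)=C/CC[C@@H]1[C@@]2(C)CCC(=O)C(C)(C)[C@H]2CC[C@@]1(C)O)CC/C=C(\C)C(=O)OCc1cn(-c2cccc(F)c2)nn1`: > 150000 nM (a limit)

Compound 3 has no exact number, because its > 150000 nM is a limit of this assay. It shares that position with one other compound, as the series shows (the limit of > 150000 nM in this assay, at which 2 of the 3 values shown sit).

Among the compounds with values here, compound 4 `C/C(=C\CC/C(C)=C/CC[C@@H]1[C@@]2(C)CCC(=O)C(C)(C)[C@H]2CC[C@@]1(C)O)CC/C=C(\C)C(=O)OCc1cn(-c2ccc(C(C)(C)C)cc2)nn1` keeps the shared core and the triazole-free description aside changes only one group: 4-(tert-butyl)phenyl in place of 3-fluorophenyl on an aromatic nitrogen. In words, 4-(tert-butyl)phenyl stands in place of 3-fluorophenyl on an aromatic nitrogen.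

The nearest guides are exchanges on that same nitrogen. One is an at least 1.1-fold lower number from compound 1 to compound 2 (0.04 log units; that floor lies within the scatter), and the other is an at least 1.1-fold higher number from compound 2 to compound 3 (0.04 log units; that floor lies within the scatter). Both floors lie within the scatter, while a step that the two limits leave unreadable from compound 1 to compound 3 cannot be sized at all. None of these steps shows that a change of this group moves the read-out, so no step beyond the scatter is expected in this assay.

The expected change is a number no higher from compound 3 to compound 4 (the limit leaves the size open). Compound 4 is estimated at 150000 nM, with an expected range of 90000 nM to 250000 nM.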

Compound 4, half-maximal inhibitory concentration: > 150000 nM
Compound 4 ended at the assay's limit; the forecaster's own chance of this, stated with the estimate: 70%; the middle value sits exactly at the limit.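

In this assay, 4-(tert-butyl)phenyl, a group of carbon only, joins 3-nitrophenyl and 3-fluorophenyl at the same limit of the assay: the limit of > 150000 nM in this assay, at which 3 of the 4 values shown sit.

Tert-butyl in place of methoxy on an aromatic carbon gives an at least 1.1-fold higher number from compound 2 to compound 4 (0.04 log units; that floor lies within the scatter), so this exchange, the only readable one to compound 4, shows no step beyond the scatter. The steps from compound 1 and from compound 3 to compound 4 cannot be read, as both ends of each are limits.

The compounds shown leave open whether any group on this aromatic nitrogen can bring the read-out clearly away from the limit. An amine or a carboxylic acid on the phenyl ring would test this, and only then could the size of a change at this position be read.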